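Ester Branching and Adenosine Receptor Binding

This account rests on a few compounds, and the source may have more. Where it says the series, first, only, none or still open, it means among the compounds named here.

The shared core carries an ester whose alkyl group varies. Compound 1 `CC1=C(C(=O)OC(C)(C)C)C(c2ccoc2)NC(=O)N1C` gives 16% in an assay on membranes from HEK293 cells for displacement of a labelled ligand from adenosine receptor A2b (Homo sapiens), read by scintillation counting, with a stated time of 30 min, tested at 1 uM (on this read-out higher numbers stand for more inhibition at the one concentration tested (going by the name of the read-out) and lower numbers for less inhibition), and compound 2 `COC(=O)C1=C(C)N(C)C(=O)NC1c1cccs1` gives 17%. Compound 3 `CC1=C(C(=O)OCC(C)C)C(c2cccs2)NC(=O)N1C` gives 2%, the lowest of the three numbers. For the measured compounds named here, the one measured step touching the ester is a number 15 percentage points lower from compound 2 to compound 3 (beyond the scatter). Compound 4 `CC1=C(C(=O)OC(C)(C)C)C(c2cccs2)NC(=O)N1C` differs from compound 3 by tert-butyl in place of isobutyl on an oxygen next to a carbonyl group. Going by the values given here, no measured step covers this exact change; compound 1, which also carries tert-butyl, shows a higher number than compound 3, but the two differ elsewhere as well. The step is therefore expected to be a number 8 percentage points higher from compound 3 to compound 4 (within the scatter), a small rise that may not exceed the scatter. Compound 4 is estimated at 10%, between 0% and 25%.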

Compound 4, a percentage reported as inhibition, at one concentration (the size of the read-out at that concentration, not a potency): 24%
Compound 4: the middle estimate sits 14 percentage points below what was measured; measured number inside the range.
By their numbers in this assay, from the lowest: compound 3; then compounds 1, 2 and 4 (each within the scatter of the next).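

In this assay, tert-butyl in place of isobutyl on an oxygen next to a carbonyl group gives a number 22 percentage points higher from compound 3 to compound 4 (beyond the scatter) even though the two groups have the same atoms, so how the chain is joined counts at this position. Tert-butyl in place of methyl gives a number 7 percentage points higher from compound 2 to compound 4 (within the scatter) and thiophen-2-yl in place of furan-3-yl gives a number 8 percentage points higher from compound 1 to compound 4 (within the scatter) so neither change separates its pair. Nothing available explains the gap between isobutyl and tert-butyl. Going by these compounds, whether a longer chain or an amine on this oxygen's chain would keep the number of compound 4 stays open, as does whether the isobutyl to tert-butyl difference holds with furan-3-yl.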